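This account rests on a few compounds, and the source may have more. Where it says the series, first, only, none or still open, it means among the compounds named here.

Measured so far:
compound 1, `Nc1nc(C(F)(F)F)cc2c1[nH]c(=O)n2Cc1ccc(NCCN2CCCCC2)nc1`, with 16 mL.min-1.g-1
compound 2, `CN(C)CCN(C)c1ccc(Cn2c(=O)[nH]c3c(N)nc(C(F)(F)F)cc32)cn1`, with 11 mL.min-1.g-1

Both numbers come from an in vitro ADME assay on microsomes from liver (Rattus norvegicus) for pharmacokinetics; on this read-out higher numbers stand for fast clearance and lower numbers for slow clearance. Among the two measured compounds, compound 1 has the highest number, yet its only neighbour, compound 2, sits within the scatter of it: a 1.5-fold lower number from compound 1 to compound 2 (0.16 log units; within the scatter). Compound 3, `CN1CCN(CCN(C)c2ccc(Cn3c(=O)[nH]c4c(N)nc(C(F)(F)F)cc43)cn2)CC1`, has not yet been measured in this assay. It differs from compound 1 in one place: methyl(2-(4-methylpiperazin-1-yl)ethyl)amino in place of (2-(piperidin-1-yl)ethyl)amino on an aromatic carbon. Among the compounds with values here, the one measured step that speaks to this kind of change is the one from compound 1 to compound 2, which also swaps the group on that same aromatic carbon next to the ring nitrogen, and it gave a difference within the scatter. On that basis no step beyond the scatter is expected for the change from compound 1 to compound 3 either. For compound 3 the number in this assay is expected near 13 mL.min-1.g-1, within a range from 6 mL.min-1.g-1 to 28 mL.min-1.g-1. The step this estimate implies, a 1.2-fold lower number from compound 1 to compound 3 (0.09 log units; within the scatter), is expected to stay inside the usual scatter.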

Compound 3, intrinsic clearance in microsomes: 15 mL.min-1.g-1
The estimate for compound 3 lay 1.2-fold (0.06 log units) below the measured number; measured number inside the range.
By their numbers in this assay, from the lowest: compounds 2, 3 and 1 (each within the scatter of the next).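

In this assay, methyl(2-(4-methylpiperazin-1-yl)ethyl)amino in place of (2-(piperidin-1-yl)ethyl)amino on the aromatic carbon next to the ring nitrogen gives a 1.1-fold lower number from compound 1 to compound 3 (0.03 log units; within the scatter) and so does not separate the two compounds. This swap replaces a six-membered non-aromatic ring with 1 hetero atom by one with 2 hetero atoms, and a group with 1 hydrogen-bond donor by one with 0, yet the difference stays inside the scatter. The second comparison isolates the group on the saturated chain carbon: 4-methylpiperazin-1-yl in place of dimethylamino gives a 1.4-fold higher number from compound 2 to compound 3 (0.13 log units; within the scatter) and shows that, among these three compounds, a ring at that point and two methyl groups on the nitrogen cannot be told apart on this read-out.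

As far as these compounds go, it remains open whether a chain ending in morpholine or a carboxylic acid, a longer chain, or a methoxy group directly on that aromatic carbon would also stay within the scatter of these three compounds. Nothing measured here explains why the numbers lie so close together.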